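Ring size at the chain amine: compound 2 to compound 4

The compounds below may be only part of what the source reports. "The series", "measured", "known", "first", "only" and "open" are said of these compounds alone.

Of the compounds shown here, three have been measured in a functional assay on MKN-45 cells (Homo sapiens) for cytotoxicity, read by MTT assay, with a stated time of 72 h; a lower number here means a stronger inhibitor, a higher number a weaker inhibitor. Compound 1 `COc1cc2c(Oc3ccc(NC(=O)c4nn(-c5ccccc5Br)c(=O)c5ccccc45)cc3F)ccnc2cc1OCCCN1CCCC1` gives 410 nM, compound 2 `COc1cc2c(Oc3ccc(NC(=O)c4nn(-c5ccc([N+](=O)[O-])cc5)c(=O)c5ccccc45)cc3F)ccnc2cc1OCCCN1CCCC1` gives 1620 nM, and compound 3 `COc1ccc(-n2nc(C(=O)Nc3ccc(Oc4ccnc5cc(OCCCN6CCCC6)c(OC)cc45)c(F)c3)c3ccccc3c2=O)cc1` gives 1320 nM. Compound 2 has the highest number of the three, but its gap to compound 3 is within the scatter, as a 1.2-fold lower number from compound 2 to compound 3 (0.09 log units; within the scatter) shows; only compound 1 stands apart, since a 4.0-fold higher number from compound 1 to compound 2 (0.60 log units; beyond the scatter) and a 3.2-fold higher number from compound 1 to compound 3 (0.51 log units; beyond the scatter) are both beyond the scatter.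

Compound 4 `COc1cc2c(Oc3ccc(NC(=O)c4nn(-c5ccc([N+](=O)[O-])cc5)c(=O)c5ccccc45)cc3F)ccnc2cc1OCCCN1CCCCC1` has not been measured. It differs from compound 2 in one place: piperidin-1-yl in place of pyrrolidin-1-yl on a saturated chain carbon, three bonds along the chain from an oxygen on an aromatic ring. For the measured compounds named here, none of the measured steps touches this part of the molecule; all three change the aromatic group on the aromatic nitrogen while the chain amine is held constant. Going by the values given here, no measured step therefore bears on this change, and the series gives no direction for it. Compound 4 is expected to show no change at the digits printed from compound 2 to compound 4 (within the scatter) in this assay, nothing beyond the scatter. Compound 4 is estimated at 1620 nM, with a range from 600 nM to 4400 nM.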

Compound 4, half-maximal inhibitory concentration: 1140 nM
Compound 4: middle estimate off by 1.4-fold (0.15 log units), on the high side; the range from low to high includes it.
By their numbers in this assay, from the lowest: compound 1; then compounds 4, 3 and 2 (each within the scatter of the next).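

For the compounds shown here, with the chain amine varied for the first time, this assay gives a 1.4-fold lower number from compound 2 to compound 4 (0.15 log units; within the scatter) and so does not separate piperidin-1-yl from pyrrolidin-1-yl at this position. On the 4-nitrophenyl compounds, the six-membered ring can stand in place of the five-membered ring at the end of the propyl chain without a change beyond the scatter. No available data explain this result.

As far as these compounds go, the comparison rests on one pair, so it remains open whether the same holds with the 2-bromophenyl group of compound 1, which gives 410 nM in this assay. The compounds shown also leave open how a morpholine ring, an open-chain dimethylamino group or a longer chain between the oxygen and the amine would fare here.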